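A few compounds are considered here, and "the series" means these few. Any claim that something is new, unique, unknown or untested is made for them only; others in the source may bear on it.

Measured so far:
Compound 1, `O=[N+]([O-])c1cc(-c2nnn(Cc3ccc(Br)cc3)n2)cc([N+](=O)[O-])c1`: in an ADME assay on CHO-K1 cells (Cricetulus griseus) for cytotoxicity, read by MTT assay, with a stated time of 24 h (a higher number here means a weaker inhibitor, a lower number a stronger inhibitor), compound 1 gives 55000 nM.
Compound 2, `O=[N+]([O-])c1cc(-c2nnn(CSc3nnnn3C3CCCCC3)n2)cc([N+](=O)[O-])c1`: in this assay compound 2 gives 140000 nM.

Both compounds share a core with two nitro groups on a benzene ring joined to a five-membered ring of four nitrogens. Of the two numbers, compound 2 has the higher one, and its gap to compound 1 lies beyond the usual scatter of this assay, so compound 2 is the weaker inhibitor of the two.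

Compound 3, `O=[N+]([O-])c1cc(-c2nnn(CSc3nnnn3-c3ccc(Cl)cc3)n2)cc([N+](=O)[O-])c1`, has not been measured. It differs from compound 2 in one place: 4-chlorophenyl in place of cyclohexyl on an aromatic nitrogen. For the measured compounds named here, no measured pair in this set makes this same change, so there is no direct guide to its effect. Going by the values given here, with only two measured compounds and no comparable step, the expected step from compound 2 to compound 3 is small, a 1.3-fold lower number from compound 2 to compound 3 (0.10 log units; within the scatter), and may not exceed the scatter in either direction.

On that basis, the estimate for compound 3 in this assay is 110000 nM, with a range from 40000 nM to 300000 nM.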

Compound 3, half-maximal inhibitory concentration: 14000 nM
Estimate against measurement, compound 3: 7.9-fold (0.90 log units) above; the whole stated range lies above it.
By their numbers in this assay, from the lowest: compound 3; then compound 1; then compound 2.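

Putting 4-chlorophenyl in place of cyclohexyl on the aromatic nitrogen gives, in this assay, a 10-fold lower number from compound 2 to compound 3 (1.00 log units; beyond the scatter) and shows that the group at this position can clearly change the result. Compound 1 and compound 2 differ in more than one place, so they could not isolate the effect of any single group. Here, the only change is from a six-membered non-aromatic ring of carbon only to a six-membered aromatic ring of carbon only that carries chlorine, and no measurement shown explains why this changes the number.

The compounds shown do not separate the contribution of the aromatic ring from that of the chlorine, so a plain phenyl group or a 4-fluorophenyl group on the same nitrogen would be informative. As far as these compounds go, it also remains open whether a straight hexyl chain or a ring carrying an amine or a carboxylic acid would follow compound 2 or compound 3, and whether the same swap would have a similar effect on a different core.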